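Removing the amide-bearing side chain from compound 1

The source may report more compounds than this note shows. Statements on the series, on what has been measured and on what is new or still open speak of the compounds shown alone.

Measured so far in an assay on cells for inhibition of cytochrome P450 11B2, mitochondrial (Homo sapiens), read by HTRF; on this read-out lower numbers stand for stronger inhibition and higher numbers for weaker inhibition:
compound 1 `CCC(=O)NCc1cncc(N2C(=O)c3ccc(Cl)cc3C2(C)C)c1` gives 282 nM
compound 2 `Cc1cccnc1C(=O)NCc1cncc(N2C(=O)c3ccc(Cl)cc3C2(C)C)c1` gives 9 nM
compound 3 `O=C1c2ccccc2CN1c1cccnc1` gives 1120 nM

Among these three numbers compound 1 stands second highest: compound 3 lies above it by a gap beyond the scatter, and compound 2 lies far below it. For the measured compounds named here, the one single-point step on record, a 31-fold lower number from compound 1 to compound 2 (1.50 log units; beyond the scatter), shows that enlarging the group on the carbonyl carbon of the side chain moves the number strongly downward.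

Compound 4 `CC1(C)c2cc(Cl)ccc2C(=O)N1c1cccnc1` goes the other way. The change is hydrogen in place of (propanoylamino)methyl on an aromatic carbon, on an aromatic carbon of a six-membered aromatic ring with one nitrogen, two atoms from the ring nitrogen and meta to a large group. Compound 4 therefore carries no side chain at all on that ring.

Going by the values given here, no measured step matches this removal exactly. The step from compound 1 to compound 2 bears on it indirectly, since it shows how much this side chain can matter. Compound 3, which also has no group on that ring but a simpler core, gives 1120 nM. A rise beyond the scatter is therefore expected, a 3.2-fold higher number from compound 1 to compound 4 (0.50 log units; beyond the scatter), with compound 4 estimated at 900 nM in this assay, in the range 300 nM to 3000 nM.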

Compound 4, half-maximal inhibitory concentration: 108 nM
Beside the measured number, compound 4's estimate is 8.3-fold (0.92 log units) above it; measured number below the stated range.
By their numbers in this assay, from the lowest: compound 2; then compound 4; then compound 1; then compound 3.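

Removing the side chain does not weaken inhibition in this assay; the step is in the opposite direction, a 2.6-fold lower number from compound 1 to compound 4 (0.42 log units; beyond the scatter), so the (propanoylamino)methyl group is not needed for the shared core to inhibit the enzyme. Having this side chain on the ring is therefore not a gain in itself, and the outcome depends on what sits on its carbonyl carbon: with ethyl there, compound 1 gives a higher number than the hydrogen-bearing compound 4, whereas compound 2, with 3-methylpyridin-2-yl there, gives 9 nM and lies below compound 4 at 108 nM on the printed values. No measurement available here gives a cause for this change of direction.

The compounds shown leave open how a smaller group at this place on the ring would behave, such as a plain aminomethyl or a carboxylic acid, since only hydrogen and the two amides can be compared. They also leave open where a longer alkyl chain or an unsubstituted phenyl on the carbonyl carbon would fall relative to the ethyl of compound 1 and the 3-methylpyridin-2-yl of compound 2.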